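A few compounds are considered here, and "the series" means these few. Any claim that something is new, unique, unknown or untested is made for them only; others in the source may bear on it.

Compound 1, `COc1cccc(COC[C@@H]2CCc3cc([C@H]4CC[C@](N)(CO)C4)ccc3C2)c1`: 40%
Compound 2, `COc1cccc(CO[C@H]2CCc3cc([C@H]4CC[C@](N)(CO)C4)ccc3C2)c1`: 13%

In a functional assay on the whole organism (strain Lewis) with Rattus norvegicus as the target, with a stated time of 24 h, at a dose of 0.3 mg/kg by the oral route (a lower number here means less inhibition, a higher number more inhibition at the dose given (going by the name of the read-out)), compound 1 stands highest of the two numbers, with compound 2 lower by a gap beyond the usual scatter. Compound 3, `COc1cccc(OC[C@@H]2CCc3cc([C@H]4CC[C@](N)(CO)C4)ccc3C2)c1`, differs from compound 1 in one place: 3-methoxyphenyl in place of 3-methoxybenzyl on an oxygen on a saturated carbon. Within the data shown here, no measured pair mirrors this change, so its direction is open from the data alone; a modest loss is expected for compound 3, perhaps not larger than the scatter, as a number 10 percentage points lower from compound 1 to compound 3 (within the scatter). Compound 3 is therefore estimated to give 30%, within a range from 5% to 60%.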

Compound 3, a percentage reported as inhibition, in the whole organism at one dose (the size of the read-out at that dose, not a potency): 80%
For compound 3 the middle estimate is 50 percentage points below the measured one, and the stated range ends below it.
By their numbers in this assay, from the lowest: compound 2; then compound 1; then compound 3.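

In this assay, the group on an oxygen on a saturated carbon proves highly sensitive to a small edit: 3-methoxyphenyl in place of 3-methoxybenzyl gives a number 40 percentage points higher from compound 1 to compound 3 (beyond the scatter). Both groups carry the same aromatic ring and the same counts of hydrogen-bond donors and acceptors, so a large step arises without a change in any of these. Nothing measured here accounts for the step.

Going by these compounds, whether an unsubstituted phenyl or a 3-chlorophenyl would hold this gain remains open. So does the effect of a longer chain, such as 2-(3-methoxyphenyl)ethyl, on this oxygen.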